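A few compounds are considered here, and "the series" means these few. Any claim that something is new, unique, unknown or untested is made for them only; others in the source may bear on it.

Among the measured compounds shown here, compound 3 `CC(=O)NC1CCN(Cc2coc3cc(Oc4nc5ccccc5s4)ccc23)CC1` gives 100 nM in an assay on isolated protein (blood, strain CD1) for inhibition of leukotriene A-4 hydrolase (Mus musculus), read by immunoassay, with stated times of 15 min and 30 min (on this read-out lower numbers stand for stronger inhibition and higher numbers for weaker inhibition), and stands second highest of the three numbers so far. For the measured compounds named here, compound 1 `c1cnc2nc(Oc3ccc4c(CN5CCCCC5)coc4c3)sc2c1` gives 21 nM and compound 2 `O=C(O)C1CCN(Cc2coc3cc(Oc4nc5ncccc5s4)ccc23)CC1` gives 280 nM; the one single-point step measured is a 13-fold higher number from compound 1 to compound 2 (1.12 log units; beyond the scatter). Compound 4 `CC(=O)NC1CCN(Cc2coc3cc(Oc4nc5ncccc5s4)ccc23)CC1` carries a group of 9 heavy atoms (6 carbon, 2 nitrogen, 1 sulfur; one five-membered aromatic ring with 2 hetero atoms, one six-membered aromatic ring with 1 hetero atom) in place of a group of 9 heavy atoms (7 carbon, 1 nitrogen, 1 sulfur; one five-membered aromatic ring with 2 hetero atoms, one six-membered aromatic ring of carbon only), on an oxygen on an aromatic ring. Going by the values given here, no measured step bears on this exchange: compound 1 and compound 2 both already hold the entering group, and compound 2 differs from compound 3 in two places, so their values show only that compound 2 sits higher in this assay. The exchange is therefore expected to give no change at the digits printed from compound 3 to compound 4 (within the scatter), a step not beyond the scatter in either direction. Compound 4 is estimated at 100 nM, within 40 nM to 250 nM.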

Compound 4, half-maximal inhibitory concentration: 17 nM
Beside the measured number, compound 4's estimate is 5.9-fold (0.77 log units) above it; measured number below the stated range.
By their numbers in this assay, from the lowest: compounds 4 and 1 (each within the scatter of the next); then compound 3; then compound 2.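

Among the compounds shown here, with acetamido held on the saturated ring carbon, the entering group with one hetero atom in its six-membered aromatic ring, in place of 1,3-benzothiazol-2-yl on the oxygen, gives a 5.9-fold lower number from compound 3 to compound 4 (0.77 log units; beyond the scatter) as the first reading of this exchange. At the saturated ring carbon, acetamido in place of carboxy gives a 16-fold lower number from compound 2 to compound 4 (1.22 log units; beyond the scatter) and stands apart, whereas acetamido in place of hydrogen gives a 1.2-fold lower number from compound 1 to compound 4 (0.09 log units; within the scatter) and does not separate the two compounds. No evidence on hand gives a cause for these steps.

From the compounds shown here alone, whether the exchange on the oxygen gives a similar step with hydrogen or carboxy on the saturated ring carbon stays open. Going by these compounds, how an amine or a longer amide chain at that carbon would read also stays open.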